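Removing the acetyl from compound 2 to reach compound 3

A few compounds are considered here, and "the series" means these few. Any claim that something is new, unique, unknown or untested is made for them only; others in the source may bear on it.

Measured so far:
Compound 1 `Nc1c(F)cc(C(=O)NO)cc1F`: 112 nM
Compound 2 `CC(=O)Nc1ccc(C(=O)NO)cc1`: 162 nM

In an assay on Sf9 cells for inhibition of protein deacetylase HDAC6 (Homo sapiens), read by fluorescence (a higher number here means a weaker inhibitor, a lower number a stronger inhibitor), compound 2 gives the larger of the two numbers, yet its gap to compound 1 lies within the scatter, so the two stand together. Compound 3 `Nc1ccc(C(=O)NO)cc1` differs from compound 2 by hydrogen in place of acetyl on a nitrogen on an aromatic ring. Among the measured compounds shown here, no pair of measured compounds traces this exact change. Compound 1 carries a free amino group as well and gives 112 nM, which suggests that the step from compound 2 to compound 3 is expected to be small, if anything a slight weakening, as a 1.5-fold higher number from compound 2 to compound 3 (0.19 log units; within the scatter). Compound 3 is therefore estimated at 250 nM, within 80 nM to 800 nM.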

Compound 3, half-maximal inhibitory concentration: 389 nM
Beside the measured number, compound 3's estimate is 1.6-fold (0.19 log units) below it, within the range that was stated.
By their numbers in this assay, from the lowest: compounds 1 and 2 (each within the scatter of the next); then compound 3.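

Measured by this assay the change from acetamido to amino gives a 2.4-fold higher number from compound 2 to compound 3 (0.38 log units; beyond the scatter) and so weakens inhibition modestly. Among the compounds shown here, this is the first single change that can be read directly, and it shows that the acetyl on this nitrogen counts for something, though not for much. Nothing at hand accounts for the change.

Still open, from the compounds shown here alone, is whether this depends on the acetyl itself or would hold for any group on that nitrogen, such as a propionyl, a methyl or a methanesulfonyl.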